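Cyclopropylmethoxy in Place of Fluoro on the Benzyl Ring

The source may hold more compounds than are shown below. What is called first, only, known or untested is meant among the compounds shown, and "the series" means these compounds.

Measured compounds:
Compound 1 `O=[N+]([O-])c1cn2c(n1)OC[C@@H](NCc1ccc(OC(F)(F)F)c(F)c1)C2` — 58.7 mL.min-1.g-1
Compound 2 `CN(Cc1ccc(OC(F)(F)F)cc1)[C@@H]1COc2nc([N+](=O)[O-])cn2C1` — 125 mL.min-1.g-1
Compound 3 `O=[N+]([O-])c1cn2c(n1)OC[C@@H](NCc1ccc(OC(F)(F)F)cc1F)C2` — 95.6 mL.min-1.g-1

These three share a core and differ in the group on the benzyl ring and at the amine. In an in vitro ADME assay on the whole organism (microsomes, liver, Mus musculus) for metabolic stability, read by LC-MS, with a stated time of 24 h, at a dose of 5 mg/kg by the intravenous route (on this read-out lower numbers stand for slow clearance and higher numbers for fast clearance), compound 3 gives 95.6 mL.min-1.g-1, the second highest of the three numbers; its gap to compound 2 and its gap to compound 1 both lie within the scatter, so the three cannot be told apart. Compound 4 `O=[N+]([O-])c1cn2c(n1)OC[C@@H](NCc1ccc(OC(F)(F)F)cc1OCC1CC1)C2` is the next compound. Its change from compound 3 is cyclopropylmethoxy in place of fluoro on an aromatic carbon. Among the compounds with values here, no measured pair shows this change, so its effect is unknown. In this assay an upward step is expected, a 1.5-fold higher number from compound 3 to compound 4 (0.17 log units; within the scatter), and compound 4 is estimated to give 140 mL.min-1.g-1, with a range of 70 mL.min-1.g-1 to 280 mL.min-1.g-1.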

Compound 4, intrinsic clearance in microsomes in the liver assay: 866 mL.min-1.g-1
For compound 4 the middle estimate is 6.2-fold (0.79 log units) below the measured one, and the stated range ends below it.
By their numbers in the liver assay, from the lowest: compounds 1, 3 and 2 (each within the scatter of the next, the first and the last beyond it); then compound 4.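

On this aromatic carbon the swap matters: in the liver assay cyclopropylmethoxy in place of fluoro gives a 9.1-fold higher number from compound 3 to compound 4 (0.96 log units; beyond the scatter), the first step tied to a single change. In a physicochemical assay for solubility, at pH 6.8 (on this read-out lower numbers stand for lower solubility and higher numbers for higher solubility), compound 3 gives 72 ug/mL and compound 4 gives 6 ug/mL. This one pair thus links the change to lower solubility as well as faster clearance: the measured solubility of compound 3, 72 ug/mL, and of compound 4, 6 ug/mL, a 12-fold lower number (1.08 log units; beyond the scatter). Still open, as far as these compounds go, is how a methoxy group or an amine on this same carbon would fare on clearance and solubility. One pair also cannot say whether the three-membered ring or the oxygen matters more.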